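Solubility at Neutral pH: Pyrazolyl Replaced by Isopropyl

The compounds below may be only part of what the source reports. "The series", "measured", "known", "first", "only" and "open" are said of these compounds alone.

Compound 1, `COc1cccc(NC(=O)c2nnn(CC3CCNCC3)c2N)c1`, gives > 250000 nM in a physicochemical assay for solubility, read by nephelometry, at pH 7.4; a higher number here means a more soluble compound, a lower number a less soluble compound; this is a limit of the assay, not a number.
Compound 2, `COc1cccc(NC(=O)c2nnn(Cc3ccc(-n4cccn4)cc3)c2N)c1`, gives 20000 nM in this assay.
Compound 3, `COc1cccc(NC(=O)c2nnn(CC3CCN(C(C)=O)CC3)c2N)c1`, gives > 250000 nM in this assay; this too is a limit.

Going by the values given here, compound 2 thus holds the only true number, while the other two sit at the limit of > 250000 nM in this assay, at which 2 of the 3 values shown sit. The change from compound 1 to compound 3, a step that the two limits leave unreadable from compound 1 to compound 3, is therefore unreadable. Compound 4, `COc1cccc(NC(=O)c2nnn(Cc3ccc(C(C)C)cc3)c2N)c1`, differs from compound 2 by isopropyl in place of 1H-pyrazol-1-yl on an aromatic carbon. Among the compounds with values here, no measured step touches this change, so no direction can be read from the data, and no step beyond the scatter is expected. Compound 4 is estimated at 12000 nM, between 3000 nM and 50000 nM, an expected step of a 1.7-fold lower number from compound 2 to compound 4 (0.22 log units; within the scatter).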

Compound 4, solubility: 14000 nM
Estimate against measurement, compound 4: 1.2-fold (0.07 log units) below; the range from low to high includes it.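

On the aromatic carbon para to a large group, isopropyl in place of 1H-pyrazol-1-yl gives a 1.4-fold lower number from compound 2 to compound 4 (0.15 log units; within the scatter) in this assay and so, at this position, a ring can give way to a group with no ring without a readable change. Far larger are an at least 17-fold lower number from compound 3 to compound 4 (1.25 log units; beyond the scatter) and an at least 17-fold lower number from compound 1 to compound 4 (1.25 log units; beyond the scatter) for the exchange of the whole 4-isopropylphenyl group. Compound 1 and compound 3 each sit at a limit, so these two sizes are only bounds: the limit of > 250000 nM in this assay, at which 2 of the 4 values shown sit.

As far as these compounds go, whether an amine or a carboxylic acid on that aromatic carbon would give a step beyond the scatter remains open.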